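Sulfonamide series: cytotoxicity step to compound 4

This account rests on a few compounds, and the source may have more. Where it says the series, first, only, none or still open, it means among the compounds named here.

Compound 3 `O=S(=O)(Nc1ccc(-c2nc3ccccc3o2)cc1)c1cccc(O)c1` in an ADME assay on HEK293 cells (Homo sapiens) for cytotoxicity, read by resazurin assay, with a stated time of 48 h (a lower number here means that less compound is tolerated, a higher number that more compound is tolerated), gives > 100000 nM, which is a limit of the assay rather than a number. Compound 1 `O=S(=O)(Nc1ccc(-c2nc3ccccc3o2)cc1)c1cccc(Cl)c1` in this assay gives > 100000 nM, also a limit. For the measured compounds named here, compound 2 `COc1ccc(Cl)cc1S(=O)(=O)Nc1ccc(-c2nc3ccccc3o2)cc1` in this assay gives 75000 nM, the only plain number in the set. Compound 3 thus stands at the limit of > 100000 nM in this assay, at which 2 of the 3 values shown sit, and its position within the series cannot be read more finely than that.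

The measured steps run an at least 1.3-fold lower number from compound 1 to compound 2 (0.12 log units; that floor lies within the scatter), a step that the two limits leave unreadable from compound 1 to compound 3 and an at least 1.3-fold higher number from compound 2 to compound 3 (0.12 log units; that floor lies within the scatter). Compound 4 `COc1ccccc1S(=O)(=O)Nc1ccc(-c2nc3ccccc3o2)cc1` is to be measured in this assay. Its change from compound 3 is 2-methoxyphenyl in place of 3-hydroxyphenyl on a sulfonyl sulfur. The step of an at least 1.3-fold higher number from compound 2 to compound 3 (0.12 log units; that floor lies within the scatter) bears on it most directly: compound 2 carries the 5-chloro-2-methoxyphenyl group and compound 4 the 2-methoxyphenyl group. The step of an at least 1.3-fold lower number from compound 1 to compound 2 (0.12 log units; that floor lies within the scatter) also concerns a methoxy entering. Both floors lie within the scatter, and the expected step for compound 4 is therefore small and towards a lower number, an at least 1.1-fold lower number from compound 3 to compound 4 (0.04 log units; that floor lies within the scatter), or none beyond the scatter. The estimate for compound 4 in this assay is 90000 nM, with a range from 45000 nM to 180000 nM, and a fair chance that only a limit is reported.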

Compound 4, half-maximal cytotoxic concentration: > 100000 nM
Compound 4 gave a limit, no number; the forecaster's own chance of this, stated with the estimate: 50%; at least 1.1-fold (0.04 log units) between middle value and limit.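

Hydrogen in place of chloro on an aromatic carbon gives, in this assay, an at least 1.3-fold higher number from compound 2 to compound 4 (0.12 log units; that floor lies within the scatter), so this single change is not shown to shift the read-out beyond the scatter. For the compounds shown here, a methoxy group on the ring is now seen without the chloro, and compound 2 remains the only compound with a plain number, while the 2-methoxyphenyl group, which has no hydrogen-bond donor, and the 3-hydroxyphenyl group, which has one, both end at a limit of the assay, so the steps joining compound 4 to compound 1 and to compound 3 cannot be read. The series now collects at a single limit: the limit of > 100000 nM in this assay, at which 3 of the 4 values shown sit.

On these data alone, how far compound 1, compound 3 and compound 4 lie from one another past that limit remains unknown, so no order among the three can be given. Also open, as far as these compounds go, is whether any group on the ring attached to the sulfonyl sulfur brings a number lower than the limit by more than the scatter, for example an amine, a carboxylic acid or a longer chain in place of the methoxy.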